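Swapping a Basic Side Chain for a Dihydroxypropyl Triazole

A few compounds are considered here, and "the series" means these few. Any claim that something is new, unique, unknown or untested is made for them only; others in the source may bear on it.

Compound 1 `CN1CCN(CCCCCn2c3c(c4ccccc42)C(=O)c2c[n+]([O-])c4ccccc4c2C3=O)CC1` is the weakest of the three compounds measured in a functional assay on MCF7 cells (Homo sapiens) for cytotoxicity, read by MTT assay, with a stated time of 72 h (a lower number here means a stronger inhibitor, a higher number a weaker inhibitor), where compound 1 gives 1260 nM. Compound 2 `O=C1c2c[n+]([O-])c3ccccc3c2C(=O)c2c1c1ccccc1n2Cc1cn([C@@H]2O[C@H](CO)[C@@H](O)[C@H](O)[C@H]2O)nn1` gives 590 nM in this assay, and compound 3 `CN1CCN(CCCCn2c3c(c4ccccc42)C(=O)c2c[n+]([O-])c4ccccc4c2C3=O)CC1` gives 100 nM.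

Among the measured compounds shown here, the only step between measured compounds that differ in one place is a 13-fold lower number from compound 1 to compound 3 (1.10 log units; beyond the scatter), a change that shortens the chain while keeping its end group. The change that leads to compound 4 `O=C1c2c[n+]([O-])c3ccccc3c2C(=O)c2c1c1ccccc1n2Cc1cn(C[C@H](O)CO)nn1` is of a different kind:

1-(2,3-dihydroxypropyl)-1H-1,2,3-triazol-4-yl in place of 4-(4-methylpiperazin-1-yl)butyl on a saturated chain carbon bound to an aromatic nitrogen

For the measured compounds named here, no measured pair repeats this exchange, so the step from compound 1 to compound 3 bears on it only indirectly, by showing that this position tolerates large swings. The nearest structural relative is compound 2, whose triazole likewise sits on a saturated chain carbon bound to the aromatic nitrogen; compound 2 gives 590 nM, a lower number than compound 1 and beyond the scatter. Compound 4, with a smaller dihydroxypropyl group in place of the sugar of compound 2, is expected to fall in a similar region. Compound 4 is therefore estimated at 500 nM in this assay, within a range from 150 nM to 1600 nM. That would be an expected step of a 2.5-fold lower number from compound 1 to compound 4 (0.40 log units; beyond the scatter).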

Compound 4, half-maximal inhibitory concentration: > 1000 nM
Compound 4: no number, only a limit (the forecaster's own chance of this, stated with the estimate: 5%); middle value at least 2.0-fold (0.30 log units) away from the limit.
By their numbers in this assay, from the lowest: compound 3; then compound 2; then compound 1.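

In this assay, compound 4 has a limit of the assay and not a number, so the step to it from compound 1 cannot be read: the limit of > 1000 nM in this assay, at which 1 of the 4 values shown sits.

The exchange of 3-(4-methylpiperazin-1-yl)propyl for 1-(2,3-dihydroxypropyl)-1H-1,2,3-triazol-4-yl on a saturated chain carbon bound to an aromatic nitrogen can still be read, and it gives an at least 10-fold higher number from compound 3 to compound 4 (1.00 log units; beyond the scatter). This position had so far shown a large step only between two chains ending in 4-methylpiperazin-1-yl, and it now shows one when that chain gives way to a triazole. Within the triazoles, 2,3-dihydroxypropyl in place of 3,4,5-trihydroxy-6-(hydroxymethyl)oxan-2-yl on an aromatic nitrogen gives an at least 1.6-fold higher number from compound 2 to compound 4 (0.22 log units; that floor lies within the scatter), and as that floor lies within the scatter, this exchange is not shown to change the result.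

The compounds shown leave open whether the higher number follows the triazole itself or what it carries, as no triazole here bears a 4-methylpiperazin-1-yl group or another amine. On these data alone, how a carboxylic acid or a longer chain on the triazole would read also stays open.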